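Changing the carbonyl group from compound 3 to compound 4

The source may hold more compounds than are shown below. What is called first, only, known or untested is meant among the compounds shown, and "the series" means these compounds.

In a functional assay on FM3A cells (Mus musculus) for antiproliferative activity, with a stated time of 48 h (a higher number here means a weaker inhibitor, a lower number a stronger inhibitor), compound 1 (`C=C(Br)C(=O)Nc1ccc(/C=C/C(=O)c2ccc(Cl)c(Cl)c2)cc1`) stands at 3200 nM and compound 2 (`C=C(Br)C(=O)Nc1ccc(/C=C/C(=O)c2ccc(Br)cc2)cc1`) at 1100 nM in this series. Compound 3 (`C=C(Br)C(=O)Nc1ccc(/C=C/C(=O)c2ccc(C)cc2)cc1`) stands at 2100 nM with no clear separation from the other two. The steps that reach it (a 1.5-fold lower number from compound 1 to compound 3 (0.18 log units; within the scatter) and a 1.9-fold higher number from compound 2 to compound 3 (0.28 log units; within the scatter)) stay within the scatter. Compound 4 (`C=C(Br)C(=O)Nc1ccc(/C=C/C(=O)c2cccs2)cc1`) differs from it by thiophen-2-yl in place of 4-methylphenyl on a carbonyl carbon with thiophen-2-yl in place of 4-methylphenyl on a carbonyl carbon. For the measured compounds named here, no measured compound holds thiophen-2-yl. All three measured steps alter the group on that carbonyl carbon, and the largest (a 2.9-fold lower number from compound 1 to compound 2 (0.46 log units; beyond the scatter)) is modest though beyond the scatter. No step beyond the scatter is therefore expected in this assay for this change. The expected step is a 1.1-fold lower number from compound 3 to compound 4 (0.02 log units; within the scatter) in size. For compound 4 the estimate is 2000 nM with an expected range from 800 nM to 5000 nM overall.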

Compound 4, half-maximal inhibitory concentration: 520 nM
For compound 4 the middle estimate is 3.8-fold (0.59 log units) above the measured one; the measured number lies below the stated range.
By their numbers in this assay, from the lowest: compound 4; then compounds 2, 3 and 1 (each within the scatter of the next, the first and the last beyond it).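

In this assay this position tolerates more than the three substituted phenyl groups suggested: thiophen-2-yl lowers the number against each of them (a 4.0-fold lower number from compound 3 to compound 4 (0.61 log units; beyond the scatter)) (a 2.1-fold lower number from compound 2 to compound 4 (0.33 log units; beyond the scatter)) (a 6.2-fold lower number from compound 1 to compound 4 (0.79 log units; beyond the scatter)). All three steps lie beyond the scatter, so compound 4 is the strongest of the four. No measurement bears on why this exchange lowers the number.

Going by these compounds, whether the sulfur atom or the smaller ring carries the gain remains open. Furan-2-yl or thiophen-3-yl on the same carbonyl carbon would help separate the two.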